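Homologation of the Carboxyalkyl Arm on Compound 2

A few compounds are considered here, and "the series" means these few. Any claim that something is new, unique, unknown or untested is made for them only; others in the source may bear on it.

Compound 1 `O=C(O)Cn1nc(Cc2nc3cc(Cl)c(OCC(F)F)cc3[nH]2)c2ccccc2c1=O` gives 15 nM.
Compound 2 `C[C@@H](C(=O)O)c1nn(Cc2cn3cc(OCC4CC4)c(Cl)cc3n2)c2ccccc2c1=O` gives 253 nM.
Compound 3 `COc1cc(OC)c(NC(=O)Cc2cn(C)c3ccccc23)cc1Cl` gives 19200 nM.

All three values come from a functional assay on CHO cells for antagonist activity at sphingosine 1-phosphate receptor 2 (Homo sapiens), read by GTPgammaS binding; a higher number here means a weaker inhibitor, a lower number a stronger inhibitor. Among the three numbers, compound 2 stands second highest. Its nearest neighbour is compound 1, whose number is lower, beyond the scatter; the furthest is compound 3, whose number is higher, again beyond the scatter. Within the data shown here, no pair among the measured compounds differs in one place only, so no single step is available as a guide.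

Compound 4 `CCC(C(=O)O)c1nn(Cc2cn3cc(OCC4CC4)c(Cl)cc3n2)c2ccccc2c1=O` is the homologue of compound 2. The change is 1-carboxypropyl in place of 1-carboxyethyl on an aromatic carbon. The 1-carboxyethyl of compound 2 carries 1 defined stereocentre, whereas no stereocentre is defined for the 1-carboxypropyl of compound 4.

Among the measured compounds shown here, since no comparable step is measured, the expectation rests on the size of the change alone: one extra carbon in the chain. Compound 4 is expected to stay close to compound 2, with the step of a 1.6-fold higher number from compound 2 to compound 4 (0.20 log units; within the scatter) expected to be small and, if anything, towards a slightly higher number. On that basis compound 4 is estimated at 400 nM in this assay, within a range from 150 nM to 1200 nM.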

Compound 4, half-maximal inhibitory concentration: 43 nM
Compound 4: middle estimate off by 9.3-fold (0.97 log units), on the high side, outside the stated range (below it).
By their numbers in this assay, from the lowest: compound 1; then compound 4; then compound 2; then compound 3.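

In this assay the change from 1-carboxyethyl to 1-carboxypropyl, 5 heavy atoms against 6, gives a 5.9-fold lower number from compound 2 to compound 4 (0.77 log units; beyond the scatter) and so makes compound 4 the stronger inhibitor of the pair. Among these compounds, with no single-place step among the earlier compounds, this is the first sign that this aromatic carbon of the shared core responds to the length of the carboxyalkyl arm, and the larger arm is the better of the two here. No measurement shown bears on why the number falls, so the step stands as an observation only.

From the compounds shown here alone, the step also joins two differences, since the 1-carboxyethyl of compound 2 has a defined stereocentre and the 1-carboxypropyl of compound 4 has none, so the share of each stays unknown, and the separate stereoisomers of compound 4 would settle it. Also open, going by these compounds, is whether the trend continues to a longer chain such as 1-carboxybutyl, or holds with a branched arm such as 1-carboxy-2-methylpropyl or with a tetrazole in place of the carboxylic acid.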